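This account rests on a few compounds, and the source may have more. Where it says the series, first, only, none or still open, it means among the compounds named here.

Measured compounds:
Compound 1 `Fc1ccc(-c2ccc(-c3ccc(-c4nc5ccccc5[nH]4)cc3)cc2)cc1`: in a functional assay on PC-3 cells (Homo sapiens) for inhibition, read by sulforhodamine B assay (a lower number here means a stronger inhibitor of growth, a higher number a weaker inhibitor of growth), compound 1 gives 41200 nM.
Compound 2 `FC(F)(F)c1ccc(-c2ccc(-c3ccc(-c4nc5ccccc5[nH]4)cc3)cc2)cc1`: in this assay compound 2 gives 45200 nM.
Compound 3 `Cc1ccc2[nH]c(-c3ccc(-c4ccc(-c5ccc(F)cc5)cc4)cc3)nc2c1`: in this assay compound 3 gives 100000 nM.

Compound 2 differs from compound 1 by trifluoromethyl in place of fluoro on an aromatic carbon, a change that produced a 1.1-fold higher number from compound 1 to compound 2 (0.04 log units; within the scatter). The core of compound 3 differs from that of compound 1 by methyl in place of hydrogen on an aromatic carbon, which produced a 2.4-fold higher number from compound 1 to compound 3 (0.39 log units; beyond the scatter). Compound 4 `Cc1ccc2[nH]c(-c3ccc(-c4ccc(-c5ccc(C(F)(F)F)cc5)cc4)cc3)nc2c1` has not been measured; it differs from compound 3 by trifluoromethyl in place of fluoro on an aromatic carbon, the same change as between compound 1 and compound 2, at the same place. Since the earlier step of a 1.1-fold higher number from compound 1 to compound 2 (0.04 log units; within the scatter) stayed within the scatter, a step of similar size is expected. For compound 4 the expected step is a 1.1-fold higher number from compound 3 to compound 4 (0.04 log units; within the scatter). Compound 4 is estimated at 110000 nM in this assay, likely between 55000 nM and 220000 nM.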

Compound 4, concentration for 50% growth inhibition: 2010 nM
Compound 4: middle estimate off by 55-fold (1.74 log units), on the high side; the measured number lies below the stated range.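

In this assay, trifluoromethyl in place of fluoro gave a 50-fold lower number from compound 3 to compound 4 (1.70 log units; beyond the scatter), so this change did not carry over from one core to the other: the same change on two cores in this assay, a 1.1-fold higher number (0.04 log units; within the scatter) from compound 1 to compound 2 and a 50-fold lower number (1.70 log units; beyond the scatter) from compound 3 to compound 4, 55-fold (1.74 log units) apart, beyond the scatter of two such steps. Methyl in place of hydrogen on an aromatic carbon likewise gave a 22-fold lower number from compound 2 to compound 4 (1.35 log units; beyond the scatter), which reverses the direction seen without trifluoromethyl: the same change on two cores in this assay, a 2.4-fold higher number (0.39 log units; beyond the scatter) from compound 1 to compound 3 and a 22-fold lower number (1.35 log units; beyond the scatter) from compound 2 to compound 4, 55-fold (1.74 log units) apart, beyond the scatter of two such steps. These four compounds thus show that the two changes do not add up independently, but they do not show why, or whether this holds on any other core.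

Going by these compounds, it remains open whether the low number of compound 4 needs trifluoromethyl specifically or would recur with chloro or a nitrile at the same place. On these data alone, the effect of an amine or a carboxylic acid there also remains open.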